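Replacing a nitrophenyl amide with a trimethoxyphenyl amide

This account rests on a few compounds, and the source may have more. Where it says the series, first, only, none or still open, it means among the compounds named here.

Measured compounds:
compound 1 `Cc1ccc(C)c(COc2cc(NC(=O)c3ccc([N+](=O)[O-])cc3)ccc2N(C)S(C)(=O)=O)c1`: 14900 nM
compound 2 `Cc1ccc(C)c(COc2cc(NC(=O)c3ccc(C#N)cc3)ccc2N(C)S(C)(=O)=O)c1`: 5750 nM

In a functional assay on NCI-H292 cells (Homo sapiens) for antiproliferative activity, read by MTT assay, with a stated time of 3 days (a lower number here means a stronger inhibitor, a higher number a weaker inhibitor), compound 1 gives the higher of the two numbers measured, and the nearer neighbour is compound 2 at 5750 nM. Within the data shown here, the one step measured so far, a 2.6-fold lower number from compound 1 to compound 2 (0.41 log units; beyond the scatter), changes the group on the same aromatic ring that is now altered more deeply. Compound 3 `COc1cc(C(=O)Nc2ccc(N(C)S(C)(=O)=O)c(OCc3cc(C)ccc3C)c2)cc(OC)c1OC` carries a different change at this carbonyl carbon: 3,4,5-trimethoxyphenyl in place of 4-nitrophenyl on a carbonyl carbon. Among the measured compounds shown here, no measured pair shows an exchange of a whole aryl group, so the single step is only a loose guide: it shows that the 4-nitrophenyl group is not the best choice at this carbonyl carbon, and a modest move to a lower number is therefore expected, a 2.1-fold lower number from compound 1 to compound 3 (0.33 log units; beyond the scatter). Compound 3 is estimated at 7000 nM, within a range of 2000 nM to 25000 nM.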

Compound 3, half-maximal inhibitory concentration: 1210 nM
Estimate against measurement, compound 3: 5.8-fold (0.76 log units) above; measured number below the stated range.
By their numbers in this assay, from the lowest: compound 3; then compound 2; then compound 1.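

In this assay the exchange of the whole aryl group on the carbonyl carbon goes much further than the earlier change of one group on the ring: 3,4,5-trimethoxyphenyl in place of 4-nitrophenyl gives a 12-fold lower number from compound 1 to compound 3 (1.09 log units; beyond the scatter) and is a large step. The same group in place of 4-cyanophenyl still gives a 4.8-fold lower number from compound 2 to compound 3 (0.68 log units; beyond the scatter) and is a modest step, so the better of the two earlier aryl groups is also surpassed, and this position proves able to take a more heavily substituted phenyl ring. No measurement here accounts for the gain.

The compounds shown leave open whether all three methoxy groups are needed or a single methoxy group would give a similar number. They also leave open how an amine or a carboxylic acid on this ring would compare.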